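Replacing one aryl group of compound 2 in a cytotoxicity test

This account rests on a few compounds, and the source may have more. Where it says the series, first, only, none or still open, it means among the compounds named here.

Compound 1 `CN1C/C(=C\c2cccnc2)C(=O)/C(=C/c2ccc(F)cc2Br)C1`: 14400 nM
Compound 2 `CN1C/C(=C\c2ccncc2)C(=O)/C(=C/c2ccc(F)cc2Br)C1`: 12400 nM

Among the measured compounds shown here, in an ADME assay on L02 cells (Homo sapiens) for cytotoxicity, read by MTT assay, with a stated time of 24 h (on this read-out lower numbers stand for stronger inhibition and higher numbers for weaker inhibition), the two measured compounds cannot be ranked, since the only step between them is a 1.2-fold lower number from compound 1 to compound 2 (0.06 log units; within the scatter). For the measured compounds named here, compound 2 therefore stands level with its single neighbour. Compound 3 `CN1C/C(=C\c2ccncc2)C(=O)/C(=C/c2ccc(C#N)cc2)C1` differs from compound 2 by one change: 4-cyanophenyl in place of 2-bromo-4-fluorophenyl on a double-bonded chain carbon bound to a double-bonded ring carbon.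

The measured step exchanged pyridin-3-yl for pyridin-4-yl, a different group from the one changing now, so it bears only indirectly on this change. Going by the values given here, no measured compound carries 4-cyanophenyl, and the data give no direction. The expectation therefore starts from compound 2 at 12400 nM, and no step beyond the scatter is expected in this assay, though with real uncertainty. The estimated result is a 1.1-fold higher number from compound 2 to compound 3 (0.05 log units; within the scatter). Compound 3 is estimated at 14000 nM, with an expected range from 6000 nM to 35000 nM.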

Compound 3, half-maximal inhibitory concentration: 14000 nM
For compound 3 middle estimate and measured number coincide at the digits printed; measured number inside the range.
By their numbers in this assay, from the lowest: compounds 2, 3 and 1 (each within the scatter of the next).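

Among the compounds shown here, until now, only pyridin-3-yl and pyridin-4-yl had been exchanged, so this is the first look at a change on the other aryl group of the shared core. In this assay, 4-cyanophenyl in place of 2-bromo-4-fluorophenyl gives a 1.1-fold higher number from compound 2 to compound 3 (0.05 log units; within the scatter) and so, although the bromine and fluorine are gone and a nitrile has entered, the two numbers cannot be told apart. Nothing available explains why these two groups read alike.

Both groups shown at this place are substituted phenyl rings, so it remains open whether an amine, a carboxylic acid or a longer alkyl chain there would give a step beyond the scatter. Going by these compounds, it also remains open how 4-cyanophenyl would read alongside pyridin-3-yl, the group carried by compound 1.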